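This account rests on a few compounds, and the source may have more. Where it says the series, first, only, none or still open, it means among the compounds named here.

Compound 1 `Nc1nc(-c2ccccc2)nc2sc(-c3ccco3)nc12` was tested in a functional assay on CHO cells for antagonist activity at adenosine receptor A2b (Homo sapiens), read by cAMP accumulation, with a stated time of 10 min; on this read-out lower numbers stand for stronger inhibition and higher numbers for weaker inhibition. In this assay compound 1 reaches only a limit of the assay, > 30000 nM, so its true standing is not fixed by a number. Compound 2 `COc1ccc(-c2nc(N)c3nc(-c4ccco4)sc3n2)cc1` carries a methoxy in place of hydrogen on an aromatic carbon and, in this assay, compound 2 likewise reaches only a limit, > 30000 nM. The step that the two limits leave unreadable from compound 1 to compound 2 cannot be read in size or direction because of the limit of > 30000 nM in this assay, at which 2 of the 2 values shown sit. Compound 3 `Nc1nc(-c2cccc(O)c2)nc2sc(-c3ccco3)nc12` differs from compound 1 by hydroxy in place of hydrogen on an aromatic carbon. Within the data shown here, the single measured step is the closest guide to this change, yet it gives no readable size, so no shift beyond the scatter can be foreseen. The step that the limit leaves unreadable from compound 1 to compound 3 is therefore expected to show nothing beyond the scatter. For compound 3 the expected value is 40000 nM, in a range from 15000 nM to 100000 nM, most likely again reported only as a limit.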

Compound 3, half-maximal inhibitory concentration: > 30000 nM
Compound 3: no number, only a limit; the forecaster's own chance of this, stated with the estimate: 80%; the middle value is on the limit's open side.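

In this assay, among these compounds, compound 1 and compound 3 each reach only a limit, so no step between them can be read in size or direction: the limit of > 30000 nM in this assay, at which 3 of the 3 values shown sit. Going by these compounds, how strongly compound 1, compound 2 and compound 3 truly inhibit, and whether hydroxy or methoxy changes this at all, stays open.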